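This account rests on a few compounds, and the source may have more. Where it says the series, first, only, none or still open, it means among the compounds named here.

In a functional assay on A549 cells (Homo sapiens) for antiproliferative activity, read by MTT assay, with a stated time of 72 h (a higher number here means a weaker inhibitor, a lower number a stronger inhibitor), compound 1 `CC(C)N1C(=O)COc2ccc(-c3cnc(Cl)c(NS(=O)(=O)c4ccc(F)cc4)c3)cc21`, with isopropyl on an amide-type nitrogen in a ring, gives 5100 nM. Compound 2 `O=C1COc2ccc(-c3cnc(Cl)c(NS(=O)(=O)c4ccc(F)cc4)c3)cc2N1`, with hydrogen there, stands at > 40000 nM, which is a limit and not a number. Compound 3 `Cc1ccc(N2C(=O)COc3ccc(-c4cnc(Cl)c(NS(=O)(=O)c5ccc(F)cc5)c4)cc32)cc1` carries 4-methylphenyl in place of that hydrogen: 4-methylphenyl in place of hydrogen on an amide-type nitrogen in a ring. For the measured compounds named here, the only measured step that bears on this is an at least 7.8-fold higher number from compound 1 to compound 2 (0.89 log units; beyond the scatter), which removes the isopropyl from that nitrogen. Putting a group back is therefore expected to lower the number, with an estimated step of an at least 6.6-fold lower number from compound 2 to compound 3 (0.82 log units; beyond the scatter). Compound 3 is expected near 6000 nM, within an estimated range of 1500 nM to 25000 nM.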

Compound 3, half-maximal inhibitory concentration: 30900 nM
Beside the measured number, compound 3's estimate is 5.2-fold (0.71 log units) below it; the measured number lies above the stated range.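

On this nitrogen, the identity of the group matters and not just the presence of one: in this assay, 4-methylphenyl in place of isopropyl gives a 6.1-fold higher number from compound 1 to compound 3 (0.78 log units; beyond the scatter), so the ring does not stand in for isopropyl. Set against hydrogen, the same group gives an at least 1.2-fold lower number from compound 2 to compound 3 (0.11 log units; that floor lies within the scatter), which shows no firm drop. Compound 2 carries a limit and not a number: the limit of > 40000 nM in this assay, at which 1 of the 3 values shown sits.

Still open, going by these compounds, is whether a smaller chain such as methyl or ethyl would match isopropyl. Also open, on these data alone, is how a plain phenyl, without its methyl, would compare with 4-methylphenyl.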